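Fluoro to hydrogen on the aromatic ring: compound 4

The compounds below may be only part of what the source reports. "The series", "measured", "known", "first", "only" and "open" are said of these compounds alone.

Of the compounds shown here, three have been measured. Compound 1 `Cc1ccnc(/C(N)=N/NC(=S)N2CCCC2)c1` gives 52.1% in a functional assay on HeLa cells (Homo sapiens) for cytotoxicity, read by MTT assay, with a stated time of 72 h, tested at 3 uM; a lower number here means less inhibition of growth, a higher number more inhibition of growth at the concentration tested. Compound 2 `N/C(=N\NC(=S)N1CCSCC1)c1ccccn1` gives 39.7% in this assay. Compound 3 `N/C(=N\NC(=S)N1CCOCC1)c1ccc(F)cn1` gives 59.7% in this assay. On these numbers compound 3 stands at the top of the three; its gap to compound 1 lies within the scatter, so the two cannot be told apart, while its gap to compound 2 lies beyond the scatter. For the measured compounds named here, no two measured compounds differ in only one place, so no step between measured compounds can be read off.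

Compound 4 `N/C(=N\NC(=S)N1CCOCC1)c1ccccn1` has not been measured. It differs from compound 3 by hydrogen in place of fluoro on an aromatic carbon. Going by the values given here, no measured pair shows what this change does on its own. Compound 4 shares the ring without fluoro with compound 2, which gives 39.7%, but the two differ elsewhere as well, so that number is no direct guide.

With nothing to anchor the change, the step from compound 3 to compound 4 is expected to be small, a number 9.7 percentage points lower from compound 3 to compound 4 (within the scatter), leaning toward a modest decrease but not clearly beyond the scatter. Compound 4 is accordingly expected to give about 50% in this assay, within a range of 35% to 65%.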

Compound 4, percent growth inhibition at one concentration: 40%
For compound 4 the middle estimate is 10 percentage points above the measured one; the measured number falls inside the stated range.
By their numbers in this assay, from the lowest: compounds 2 and 4 (each within the scatter of the next); then compounds 1 and 3 (each within the scatter of the next).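

In this assay, for the compounds shown here, hydrogen in place of fluoro, on an aromatic carbon two atoms from the ring nitrogen and para to a large group, gives a number 19.7 percentage points lower from compound 3 to compound 4 (beyond the scatter); this is the first single-place reading at this position, and it shows that growth inhibition at the concentration tested depends on whether fluoro is present there, at least with morpholin-4-yl on the thiocarbonyl carbon. On the ring without fluoro, morpholin-4-yl in place of thiomorpholin-4-yl gives a number 0.3 percentage points higher from compound 2 to compound 4 (within the scatter), so compound 2 and compound 4 cannot be told apart and this swap shows no effect of its own in that setting. No measured property of these compounds is available to explain either step.

The compounds shown leave open whether chloro, methoxy or an amine on the same aromatic carbon would read like fluoro or like hydrogen. They also leave open whether the fluoro step carries over to compounds with thiomorpholin-4-yl or another ring on the thiocarbonyl carbon, so it rests on a single pair for now.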